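The source may report more compounds than this note shows. Statements on the series, on what has been measured and on what is new or still open speak of the compounds shown alone.

Series in a functional assay on K562 cells (Homo sapiens) for inhibition, read by trypan blue exclusion, with a stated time of 72 h; a lower number here means a stronger inhibitor, a higher number a weaker inhibitor:
- Compound 1 `Cn1c(=O)c(S(=O)(=O)c2ccc(C(=O)O)cc2)cc2cnc(Nc3ccc4[nH]ccc4c3)nc21`: 5000 nM
- Compound 2 `Cn1c(=O)c(C(=O)Nc2ccc(F)cc2F)cc2cnc(Nc3ccc4[nH]ccc4c3)nc21`: 5000 nM
- Compound 3 `O=c1c(S(=O)(=O)c2ccc(F)cc2F)cc2cnc(Nc3ccc4[nH]ccc4c3)nc2n1C1CCCC1`: 5000 nM

Compound 2, at 5000 nM, stands level with compound 1 and compound 3 in this assay. The next compound is compound 4 `Cn1c(=O)c(S(=O)(=O)Cc2ccc(F)cc2)cc2cnc(Nc3ccc4[nH]ccc4c3)nc21`, where (4-fluorobenzyl)sulfonyl stands in place of (2,4-difluorophenyl)carbamoyl on an aromatic carbon: (4-fluorobenzyl)sulfonyl in place of (2,4-difluorophenyl)carbamoyl on an aromatic carbon. Going by the values given here, no single-place step between measured compounds is available to size this change. The sulfonyl compound 1 and compound 3 read the same as compound 2, so no shift beyond the scatter is expected in this assay. The expected result is no change at the digits printed from compound 2 to compound 4 (within the scatter). Compound 4 is estimated at 5000 nM, with an expected range of 2000 nM to 10000 nM.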

Compound 4, half-maximal inhibitory concentration: 30000 nM
The estimate for compound 4 lay 6.0-fold (0.78 log units) below the measured number, outside the stated range (above it).
By their numbers in this assay, from the lowest: compounds 1, 2 and 3 (each within the scatter of the next); then compound 4.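

In this assay, this aromatic carbon proves sensitive to the group it carries: (4-fluorobenzyl)sulfonyl in place of (2,4-difluorophenyl)carbamoyl gives a 6.0-fold higher number from compound 2 to compound 4 (0.78 log units; beyond the scatter), and 4-fluorobenzyl in place of 4-carboxyphenyl on the sulfonyl sulfur gives a 6.0-fold higher number from compound 1 to compound 4 (0.78 log units; beyond the scatter). Compound 1 and compound 2 read level, so neither the earlier sulfonyl nor the carbamoyl group revealed this sensitivity.

Going by these compounds, whether a longer chain such as 2-phenylethyl on the sulfonyl sulfur, or an amine on the benzyl ring, would move the number further remains open. Nothing available explains the shift.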